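The source may report more compounds than this note shows. Statements on the series, on what has been measured and on what is new or still open speak of the compounds shown alone.

Of the compounds shown here, three have been measured in a functional assay on the whole organism (blood, strain albino) with Mus musculus as the target, with stated times of 6 days and 4 h, at a dose of 0.4 mmol/kg by the oral route; on this read-out higher numbers stand for more inhibition at the one dose given (going by the name of the read-out) and lower numbers for less inhibition. Compound 2, `Cc1cc(C(=O)O)nn1-c1ccc(S(=O)(=O)NC(=S)Nc2ccccc2)cc1`, gives 0% in this assay. Compound 1, `Cc1cc(C(=O)O)nn1-c1ccc(S(=O)(=O)NC(=S)NC2CCCCC2)cc1`, carries the change cyclohexyl in place of phenyl on an amide-type nitrogen relative to compound 2, and in this assay compound 1 gives 1%, a step of a number 1 percentage points higher from compound 2 to compound 1 (within the scatter). Compound 3, `Cc1cc(C)n(-c2ccc(S(=O)(=O)NC(=S)Nc3ccccc3)cc2)n1`, differs from compound 2 at the core; in this assay compound 3 gives -3%, a step of a number 3 percentage points lower from compound 2 to compound 3 (within the scatter). All three numbers lie within the usual scatter of one another, so none of them can be set apart from the others.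

Compound 4, `Cc1cc(C)n(-c2ccc(S(=O)(=O)NC(=S)NC3CCCCC3)cc2)n1`, has not been measured. It differs from compound 3 by cyclohexyl in place of phenyl on an amide-type nitrogen, the same change that separates compound 1 from compound 2; the two cores differ by methyl in place of carboxy on an aromatic carbon. Because that earlier change gave a number 1 percentage points higher from compound 2 to compound 1 (within the scatter), compound 4 is expected to show a step of a number 3 percentage points higher from compound 3 to compound 4 (within the scatter), an expectation that rests on a single earlier pair and on the flat picture across all three measured compounds. Compound 4 is therefore estimated at 0%, with a range expected from -10% to 10%.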

Compound 4, a percentage reported as inhibition, in the whole organism at one dose (the size of the read-out at that dose, not a potency): < 2%
Compound 4 was reported as a limit; the forecaster's own chance of this, stated with the estimate: 0%; the middle value is on the limit's open side.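

Compound 4 is reported in this assay as a limit, < 2%, and not as a number. Among these compounds, no step to compound 4 can be read, either from compound 3 or from compound 1. The compounds shown leave open whether cyclohexyl in place of phenyl on an amide-type nitrogen changes the read-out on the core of compound 3.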